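A few compounds are considered here, and "the series" means these few. Any claim that something is new, unique, unknown or untested is made for them only; others in the source may bear on it.

Measured compounds:
Compound 1 `COc1cc2c(c(OC)c1OC)CCN(CCC(=O)c1c(C)c(OC)c(OC)c(OC)c1OC)C2` gives > 1000 nM in an assay on membranes from brain for displacement of a labelled ligand from Sigma non-opioid intracellular receptor 1 (Cavia porcellus), read by scintillation counting, with a stated time of 120 min (on this read-out lower numbers stand for stronger inhibition and higher numbers for weaker inhibition), a limit of the assay.
Compound 2 `COc1cc2c(cc1OC)CN(CCCC(=O)c1c(C)c(OC)c(OC)c(OC)c1OC)CC2` gives > 1000 nM in this assay, again a limit.

Compound 2 thus stands at a limit and not at a number: the limit of > 1000 nM in this assay, at which 2 of the 2 values shown sit. Going by the values given here, no step between measured compounds can be read from these two values. Compound 3 `COc1cc2c(c(OC)c1OC)CCN(CCCC(=O)c1c(C)c(OC)c(OC)c(OC)c1OC)C2` differs from compound 2 by methoxy in place of hydrogen on an aromatic carbon. With both known values sitting at the limit, no change beyond the scatter is expected from this replacement, and a limit is again the likely outcome. Compound 3 is expected at 3000 nM, within 800 nM to 20000 nM. The step this expectation implies is a step that the limit leaves unreadable from compound 2 to compound 3.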

Compound 3, inhibition constant: > 1000 nM
Compound 3 was reported as a limit; the forecaster's own chance of this, stated with the estimate: 80%; the middle value is on the limit's open side.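

Going by these compounds alone, compound 3 gives > 1000 nM in this assay, a limit of the assay, and no step from compound 2 to compound 3 can be read. The compounds shown leave open what change to the shared core would give a measurable value.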